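Swapping the benzyl substituent in an oxadiazole sulfonamide series

A few compounds are considered here, and "the series" means these few. Any claim that something is new, unique, unknown or untested is made for them only; others in the source may bear on it.

Three measured compounds share a common core. Compound 1 `COc1ccc(Cc2nnc(CN(c3cccc(C(F)(F)F)c3C)S(=O)(=O)c3ccc(C)cc3)o2)cc1` gives 63.1 nM in an assay on CHO cells for displacement of a labelled ligand from prostaglandin E2 receptor EP1 subtype (Homo sapiens); on this read-out higher numbers stand for weaker inhibition and lower numbers for stronger inhibition. Compound 2 `CCOc1ccc(Cc2nnc(CN(c3cccc(Cl)c3Cl)S(=O)(=O)c3ccc(C)cc3)o2)cc1` gives 6.31 nM in this assay. Compound 3 `Cc1ccc(S(=O)(=O)N(Cc2nnc(Cc3ccc(C(F)(F)F)cc3)o2)c2cccc(Cl)c2C)cc1` gives 50.1 nM in this assay, the second highest of the three numbers; its nearest neighbour is compound 1, whose value lies within the scatter, and the furthest is compound 2, whose value lies beyond the scatter on the lower side.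

Compound 4 `Cc1ccc(S(=O)(=O)N(Cc2nnc(Cc3ccccc3Cl)o2)c2cccc(Cl)c2C)cc1` differs from compound 3 in one place: 2-chlorophenyl in place of 4-(trifluoromethyl)phenyl on a saturated chain carbon bound to an aromatic carbon. Going by the values given here, no measured pair in this set carries that same change, so no direct step is available. Compounds 1 and 2 carry a methoxyphenyl and an ethoxyphenyl at that position and differ also elsewhere, so they give no clean guide. The step from compound 3 to compound 4 is therefore expected to be small, estimated at a 1.2-fold higher number from compound 3 to compound 4 (0.08 log units; within the scatter) in this assay, in no firm direction. Compound 4 is accordingly expected to give about 60 nM in this assay, with a range from 15 nM to 250 nM.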

Compound 4, half-maximal inhibitory concentration: 79.4 nM
The estimate for compound 4 lay 1.3-fold (0.12 log units) below the measured number; low and high end bracket the measured number.
By their numbers in this assay, from the lowest: compound 2; then compounds 3, 1 and 4 (each within the scatter of the next).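

Going by these compounds alone, with the rest of the molecule held fixed, the change from 4-(trifluoromethyl)benzyl to 2-chlorobenzyl gives the first clean reading at this position: in this assay it amounts to a 1.6-fold higher number from compound 3 to compound 4 (0.20 log units; within the scatter). On this pair, then, the two substituted phenyl groups on this saturated chain carbon cannot be told apart, although they differ in both the substituent and its printed ring position. Nothing measured here bears on why the two read alike.

As far as these compounds go, compounds 1 and 2 differ from these two in more than one place, so it remains open whether their methoxyphenyl and ethoxyphenyl groups would read the same way on the aryl group of compound 3. The compounds shown also leave open how this position would respond to a phenyl ring carrying an amine or a carboxylic acid.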